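Benzyl in place of 3-methylbut-2-en-1-yl on compound 1

The compounds below may be only part of what the source reports. "The series", "measured", "known", "first", "only" and "open" are said of these compounds alone.

Compound 1 `CC(C)=CCn1cnc2c(Nc3cccc(Cl)c3)nc(N[C@H]3CC[C@H](N)CC3)nc21` gives 80 nM in a functional assay on EOL1 cells (Homo sapiens) for inhibition, read by fluorescence, with a stated time of 72 h (on this read-out higher numbers stand for weaker inhibition of growth and lower numbers for stronger inhibition of growth), the lowest of the three numbers shown. Compound 3 `COc1cc(Nc2nc(N[C@H]3CC[C@H](N)CC3)nc3c2ncn3CCC(C)C)cc(OC)c1` sits nearest, with 140 nM, within the scatter of compound 1; compound 2 `COc1ccc(Nc2nc(N[C@H]3CC[C@H](N)CC3)nc3c2ncn3CCC(C)C)c(OC)c1` is furthest, with 630 nM. Within the data shown here, the one measured step, a 4.5-fold lower number from compound 2 to compound 3 (0.65 log units; beyond the scatter), concerns the aryl group on a nitrogen on an aromatic ring and leaves the saturated chain carbon bound to an aromatic nitrogen untouched. Compound 4 `N[C@H]1CC[C@H](Nc2nc(Nc3cccc(Cl)c3)c3ncn(Cc4ccccc4)c3n2)CC1` differs from compound 1 by phenyl in place of 2-methylprop-1-en-1-yl on a saturated chain carbon bound to an aromatic nitrogen. Among the measured compounds shown here, no measured pair bears on this change, so no step beyond the scatter is expected in this assay, in either direction, and the range is kept wide for want of a precedent. Compound 4 is therefore expected to give 100 nM (range 35 nM to 300 nM). The expected step is a 1.3-fold higher number from compound 1 to compound 4 (0.10 log units; within the scatter).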

Compound 4, concentration for 50% growth inhibition: 380 nM
Compound 4: the middle estimate sits 3.8-fold (0.58 log units) below what was measured; the measured number lies above the stated range.
By their numbers in this assay, from the lowest: compounds 1 and 3 (each within the scatter of the next); then compounds 4 and 2 (each within the scatter of the next).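

In this assay this place, on a saturated chain carbon bound to an aromatic nitrogen, proves sensitive to its group, with a 4.8-fold higher number from compound 1 to compound 4 (0.68 log units; beyond the scatter) for phenyl in place of 2-methylprop-1-en-1-yl. Among these compounds, the earlier step changed only the aryl group on the other nitrogen, so this is the first reading here, and benzyl does not stand in for 3-methylbut-2-en-1-yl. Nothing available gives a reason for this step.

Open, on these data alone, is whether the aromatic ring itself accounts for the step. Cyclohexylmethyl at this place would test that, and a benzyl carrying a methoxy group would show whether the ring tolerates substitution.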